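A few compounds are considered here, and "the series" means these few. Any claim that something is new, unique, unknown or untested is made for them only; others in the source may bear on it.

Measured in a functional assay on the whole organism for antagonist activity, with Mus musculus as the target (on this read-out higher numbers stand for an effect only at larger amounts of compound and lower numbers for an effect already at smaller amounts), each of the three values is a limit of the assay and not a number:

Compound 1, `COc1cc(N)c(Cl)cc1NC(=O)C1CCN(CC2CC2)CC1`: > 10 mg/kg
Compound 2, `CCCCN1CCC(C(=O)Nc2cc(Cl)c(N)cc2OC)CC1`: > 10 mg/kg
Compound 3, `COc1cc(N)c(Cl)cc1NC(=O)C1CCN(CC2CCCCCC2)CC1`: > 10 mg/kg

Compound 3 therefore stands at the upper edge of what this assay reports, and so do its two neighbours, because of the limit of > 10 mg/kg in this assay, at which 3 of the 3 values shown sit. The three differ only in the group on a saturated chain carbon bound to an amine nitrogen in a ring: cyclopropyl, propyl or cycloheptyl. Since every value is a limit, none of the steps between them can be read: a step that the two limits leave unreadable from compound 1 to compound 2, a step that the two limits leave unreadable from compound 1 to compound 3 and a step that the two limits leave unreadable from compound 2 to compound 3. The measured compounds thus show only that small and large saturated groups at that position all leave the effect beyond the tested dose range.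

Compound 4, `COc1cc(N)c(Cl)cc1NC(=O)C1CCN(Cc2ccc(C)c(C)c2)CC1`, replaces the saturated ring with an aromatic one: 3,4-dimethylphenyl in place of cycloheptyl on a saturated chain carbon bound to an amine nitrogen in a ring. Within the data shown here, no measured step bears on an aromatic group at this position, so no direction can be derived from the neighbours; the expected step of a number no higher from compound 3 to compound 4 (the limit leaves the size open) is set to none beyond the scatter. For compound 4 the estimate is 10 mg/kg, with a range from 3 mg/kg to 30 mg/kg, and a limit is again the more likely outcome.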

Compound 4, dose for half-maximal effect: > 8 mg/kg
Compound 4 was reported as a limit (the forecaster's own chance of this, stated with the estimate: 65%); the middle value is on the limit's open side.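

In this assay compound 4 gives > 8 mg/kg as a limit of the assay and not a number. Among these compounds, compound 1, compound 2 and compound 3 also stand at limits, so no step from any of them to compound 4 can be read. The compounds shown leave open how cyclopropyl, propyl, cycloheptyl and 3,4-dimethylphenyl truly compare, and whether any of them gives a half-maximal effect at a readable dose.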